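Trading an amino group for a piperidinyl ester

This account rests on a few compounds, and the source may have more. Where it says the series, first, only, none or still open, it means among the compounds named here.

In an ADME assay on L6 cells (Rattus norvegicus) for cytotoxicity, read by resazurin assay, with a stated time of 72 h (a higher number here means a weaker inhibitor, a lower number a stronger inhibitor), compound 1 (`NC1CC2(N3CCCC3)CC(c3ccccc3)C1C(c1ccccc1)C2`) reads 38100 nM and compound 2 (`CCN(CC)CC(=O)OC1CC2(N(C)C)CC(c3ccccc3)C1C(c1ccccc1)C2`) reads 30100 nM within the usual scatter of each other. Compound 3 (`CN1CCN(CC(=O)N2CCC3(N(C)C)CC(c4ccccc4)C2C(c2ccccc2)C3)CC1`) reads 195000 nM as a clearly higher number than compound 1, which therefore stands well under it. Compound 4 (`O=C(CN1CCCCC1)OC1CC2(N3CCCC3)CC(c3ccccc3)C1C(c1ccccc1)C2`) keeps the core of compound 1 with one change ((((piperidin-1-yl)methyl)carbonyl)oxy in place of amino on a saturated ring carbon) that puts (((piperidin-1-yl)methyl)carbonyl)oxy in place of amino on a saturated ring carbon. Among the compounds with values here, no measured pair shows this change alone. Compound 2 also carries an ester ending in an amine and reads 30100 nM within the scatter of compound 1, so no shift beyond the scatter is expected. The estimated step is small (a 1.4-fold lower number from compound 1 to compound 4 (0.13 log units; within the scatter)). The expected value for compound 4 is 28000 nM with an estimated range (9000 nM to 85000 nM).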

Compound 4, half-maximal inhibitory concentration: 14200 nM
Compound 4: middle estimate off by 2.0-fold (0.29 log units), on the high side; measured number inside the range.
By their numbers in this assay, from the lowest: compound 4; then compounds 2 and 1 (each within the scatter of the next); then compound 3.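

In this assay, putting (((piperidin-1-yl)methyl)carbonyl)oxy in place of amino on this saturated ring carbon gives a 2.7-fold lower number from compound 1 to compound 4 (0.43 log units; beyond the scatter), a modest step but one beyond the scatter. Within the data shown here, this is the first change in a single place here, and it shows that this carbon can carry a much larger group, with a lower number rather than a higher one. Nothing measured here explains the step.

As far as these compounds go, the ester link and the piperidine ring changed together, so their shares remain unknown. A simple acetyl ester or a morpholine-ended ester at this carbon would help separate them.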